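Replacing ethoxycarbonyl with hydroxymethyl in a weakly cytotoxic series

The source may hold more compounds than are shown below. What is called first, only, known or untested is meant among the compounds shown, and "the series" means these compounds.

In a functional assay on SW480 cells (Homo sapiens) for cytotoxicity, read by MTT assay, with a stated time of 48 h (on this read-out lower numbers stand for stronger inhibition and higher numbers for weaker inhibition), compound 1 (`CCOC(=O)[C@@]1(C(=O)Nc2ccccc2)C[C@@H]1c1cc(OC)c(OC)c(OC)c1`) gives > 100000 nM, which is a limit of the assay. Compound 2 (`CCOC(=O)C1(C(=O)Nc2ccccc2)CC1c1cc(OC)c(OC)c(OC)c1`) gives 49000 nM; > 100000 nM (2 entries). Some of those entries are limits of the assay and not numbers. Within the data shown here, compound 3 (`CCOC(=O)[C@]1(C(=O)Nc2ccccc2)C[C@@H]1c1cc(OC)c(OC)c(OC)c1`) gives 31700 nM, and it is the only compound of the three with a single number and no limit beside it.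

The change to compound 4 (`COc1cc([C@H]2C[C@]2(CO)C(=O)Nc2ccccc2)cc(OC)c1OC`) puts hydroxymethyl in place of ethoxycarbonyl on a saturated ring carbon. Among the measured compounds shown here, the only measured step is an at least 3.1-fold lower number from compound 1 to compound 3 (0.49 log units; beyond the scatter), and it comes with the fact that compounds 1 and 3 differ only in the configuration as drawn. That step concerns configuration alone, so it shows that this series can respond to a small structural change but gives no size for the exchange of groups. For the measured compounds named here, no measured compound lacks the ethoxycarbonyl group.

Compound 3 at 31700 nM is the starting point. A result for compound 4 at the limit of the assay is also possible. No step beyond the scatter is expected in this assay, with any drift more likely toward a higher number. The expected step is a 1.3-fold higher number from compound 3 to compound 4 (0.10 log units; within the scatter). For compound 4 the estimate is 40000 nM, with an expected range from 15000 nM to 100000 nM.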

Compound 4, half-maximal inhibitory concentration: > 100000 nM
Compound 4 gave a limit, no number; the forecaster's own chance of this, stated with the estimate: 35%; middle value at least 2.5-fold (0.39 log units) from the limit.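

In this assay, among these compounds, the exchange of ethoxycarbonyl for hydroxymethyl on a saturated ring carbon gives an at least 3.1-fold higher number from compound 3 to compound 4 (0.49 log units; beyond the scatter), the first step that concerns a group and not configuration alone. Compound 4 gives > 100000 nM, which is a limit of the assay and not a number, so only the lower bound of the step can be read. At this position, the weak cytotoxicity of compound 3 is not kept after the exchange, making ethoxycarbonyl the better of the two groups seen here, although this rests on a single pair and on a read-out with a crowded upper end: the limit of > 100000 nM in this assay, at which 2 of the 4 values shown sit.

The compounds shown leave open how a carboxylic acid, a methyl ester or a longer chain ending in hydroxyl would read at this position against compound 3 at 31700 nM. Also open, going by these compounds, is how hydroxymethyl would read in the opposite configuration at the ring carbon, and whether any group at this position can give a number well below that of compound 3.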